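Urea-to-amide change on a pyrazole series

The source may report more compounds than this note shows. Statements on the series, on what has been measured and on what is new or still open speak of the compounds shown alone.

Measured so far:
compound 1 `COc1cc(Cl)cc(-c2nn(-c3cccc(NC(=O)Nc4ccc(Cl)c(Cl)c4)c3)cc2-c2ccncc2)c1`: -32%
compound 2 `COc1cc(Cl)cc(-c2nn(-c3cccc(NC(=O)Nc4cccc(C(F)(F)F)c4)c3)cc2-c2ccncc2)c1`: -82%

In a functional assay on UACC-62 cells (Homo sapiens) for inhibition, read by sulforhodamine B assay, with a stated time of 48 h, tested at 100 uM (a lower number here means a stronger effect, a higher number a weaker effect of the compound at the concentration tested), compound 2 gives -82%, the lowest of the two numbers; its nearest neighbour is compound 1, and the step of a number 50 percentage points lower from compound 1 to compound 2 (beyond the scatter) lies beyond the scatter. Compound 3 `COc1cc(Cl)cc(-c2nn(-c3cccc(NC(=O)c4cccc(C(F)(F)F)c4)c3)cc2-c2ccncc2)c1` is not yet measured. It differs from compound 2 by 3-(trifluoromethyl)phenyl in place of (3-(trifluoromethyl)phenyl)amino on a carbonyl carbon. For the measured compounds named here, the only measured step, a number 50 percentage points lower from compound 1 to compound 2 (beyond the scatter), changes the aryl group on the amide-type nitrogen while keeping the urea; no measured pair changes the linker itself, so there is no precedent for this step. With the donor removed and the linker shortened, a move back towards weaker effect is expected, a number 42 percentage points higher from compound 2 to compound 3 (beyond the scatter), but with wide uncertainty. Compound 3 is estimated at -40% in this assay, with a range from -90% to 20%.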

Compound 3, a percentage reported as activity, at one concentration (the size of the read-out at that concentration, not a potency): 40%
For compound 3 the middle estimate is 80 percentage points below the measured one; measured number outside the range, above it.
By their numbers in this assay, from the lowest: compound 2; then compound 1; then compound 3.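

In this assay the urea nitrogen on the carbonyl carbon proves decisive: replacing (3-(trifluoromethyl)phenyl)amino with 3-(trifluoromethyl)phenyl gives a number 122 percentage points higher from compound 2 to compound 3 (beyond the scatter), and the number changes sign. Measured against the 3,4-dichlorophenyl urea, the amide gives a number 72 percentage points higher from compound 1 to compound 3 (beyond the scatter), so compound 3 stands above both ureas, and the linker change outweighs the aryl change seen earlier, a number 50 percentage points lower from compound 1 to compound 2 (beyond the scatter). No measurement available on these compounds accounts for this reversal.

Open, as far as these compounds go, is whether the difference follows the amide hydrogen of the urea or the length of the linker; a urea with a methyl group on that nitrogen, or an amide with a methylene carbon in its place, would separate the two. Also open, from the compounds shown here alone, is how the 3,4-dichlorophenyl group behaves on the amide.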